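Trading phenyl for isobutyl in compound 2

A few compounds are considered here, and "the series" means these few. Any claim that something is new, unique, unknown or untested is made for them only; others in the source may bear on it.

Of the compounds shown here, two have been measured so far in a physicochemical assay for lipophilicity, read by HPLC (a lower number here means a more polar compound, a higher number a more lipophilic compound), and their numbers differ clearly. Compound 1 (`CN(C)CC(C)(C)COc1ccc(NC(=O)Nc2cccnc2Oc2ccccc2C(C)(C)C)cc1`) gives 5.1 while compound 2 (`CC(C)(C)c1ccccc1Oc1ncccc1NC(=O)Nc1ccc(OCC2CCN(Cc3ccccc3)CC2)cc1F`) gives 5.8 as the higher of the two numbers, a gap beyond the scatter. Compound 3 (`CC(C)CCN1CCC(COc2ccc(NC(=O)Nc3cccnc3Oc3ccccc3C(C)(C)C)c(F)c2)CC1`) has isobutyl in place of phenyl on a saturated chain carbon bound to an amine nitrogen in a ring and is otherwise the same as compound 2. Cut one bond further out, this reads benzyl to isopentyl. Going by the values given here, no two measured compounds show a change in one place only, so the data offer no direct guide. Both groups contain only carbon and neither carries a charge, so with compound 2 at 5.8 as the starting point, only a small downward step is expected, possibly within the scatter. The estimated step is a number 0.20 log units lower from compound 2 to compound 3 (within the scatter) in this assay for this change. Compound 3 is expected at 5.6 with an estimated range from 5.1 to 6.1 in this measurement.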

Compound 3, partition coefficient: 5.5
The estimate for compound 3 lay 0.10 log units above the measured number, within the range that was stated.
By their numbers in this assay, from the lowest: compound 1; then compounds 3 and 2 (each within the scatter of the next).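

this assay now has its first pair of compounds that differ in one place only: putting isobutyl in place of phenyl on a saturated chain carbon bound to an amine nitrogen in a ring gives a number 0.30 log units lower from compound 2 to compound 3 (within the scatter). At this position, then, a six-membered aromatic ring of carbon only can give way to a group with no ring and fewer heavy atoms, with no change that this measurement can tell apart from repeat scatter. No measured evidence here speaks to the reason for this result.

As far as these compounds go, both groups contain only carbon, so how a group with other atoms, such as a carboxylic acid or an amine, would read at this place in this assay stays open. A single step also cannot show whether the same swap would read alike on the core of compound 1.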